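This account rests on a few compounds, and the source may have more. Where it says the series, first, only, none or still open, it means among the compounds named here.

Measured so far:
Compound 1, `Cc1ccccc1NCc1nnc(-c2ccccc2-c2ccccc2)s1`: in a functional assay on the whole organism with Mus musculus as the target (on this read-out higher numbers stand for an effect only at larger amounts of compound and lower numbers for an effect already at smaller amounts), compound 1 gives > 200 mg/kg, which is a limit of the assay rather than a number.
Compound 2, `CC(N)c1nnc(-c2ccccc2-c2ccccc2)s1`: in this assay compound 2 gives 21 mg/kg.

Going by the values given here, compound 2 therefore stands as the only real number in this assay; the other result is the limit of > 200 mg/kg in this assay, at which 1 of the 2 values shown sits. Compound 3, `NCc1nnc(-c2ccccc2-c2ccccc2)s1`, has not yet been measured. It differs from compound 2 by hydrogen in place of methyl on a saturated chain carbon bound to an amine nitrogen and an aromatic carbon; cut one bond further out, the change reads 1-aminoethyl to aminomethyl. Among the compounds with values here, no measured pair differs in just this way, so there is no step to lean on. With compound 2 at 21 mg/kg as the only anchor, compound 3 is expected to sit a 1.2-fold higher number from compound 2 to compound 3 (0.08 log units; within the scatter), a shift no larger than the usual scatter and in no set direction. Compound 3 is thus estimated at 25 mg/kg, within 7 mg/kg to 80 mg/kg.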

Compound 3, dose for half-maximal effect: 20 mg/kg
Compound 3: middle estimate off by 1.3-fold (0.10 log units), on the high side; measured number inside the range.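

On the saturated chain carbon bound to an amine nitrogen and an aromatic carbon, hydrogen in place of methyl gives a 1.1-fold lower number from compound 2 to compound 3 (0.02 log units; within the scatter), so in this assay either group serves equally well at this position. On the amine nitrogen, hydrogen in place of 2-methylphenyl gives an at least 10-fold lower number from compound 1 to compound 3 (1.00 log units; beyond the scatter), which makes the amine nitrogen the place where these compounds show a clear difference. Going by these compounds, the true size of that step stays unknown, since compound 1 gives a limit of the assay and not a number: the limit of > 200 mg/kg in this assay, at which 1 of the 3 values shown sits.

On these data alone, how much larger a group the chain carbon can carry remains open, for example an ethyl or a longer chain. Also open, as far as these compounds go, is whether a small group on the amine nitrogen, such as methyl, behaves more like hydrogen or more like 2-methylphenyl.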